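Dichlorophenyl in Place of Methylphenyl on the Cinnamate

This account rests on a few compounds, and the source may have more. Where it says the series, first, only, none or still open, it means among the compounds named here.

Compound 1, `O=C(/C=C/c1ccc(Cl)c(Cl)c1)Oc1ccc(/C=C2\CCCCC2=O)cc1`, is the plainer member of this small set. In a functional assay on P388 cells (Mus musculus) (a higher number here means a weaker inhibitor, a lower number a stronger inhibitor), compound 1 returns only a limit, > 50000 nM, and no number. Compound 2, `Cc1ccc(/C=C/C(=O)Oc2ccc(/C=C3\CCCC(CN(C)C)C3=O)cc2)cc1`, carries a dimethylaminomethyl group that compound 1 lacks, and in this assay compound 2 gives 1290 nM. Among the compounds with values here, that is the only numbered value; compound 1 accounts for (the limit of > 50000 nM in this assay, at which 1 of the 2 values shown sits). Compound 3, `CN(C)CC1CCC/C(=C\c2ccc(OC(=O)/C=C/c3ccc(Cl)c(Cl)c3)cc2)C1=O`, keeps the dimethylaminomethyl group of compound 2 and differs from it by 3,4-dichlorophenyl in place of 4-methylphenyl on a double-bonded chain carbon bound to a double-bonded chain carbon. Within the data shown here, no measured pair covers this exchange, so the data give no direct guide to its size. The step from compound 2 to compound 3 is expected to be small, a 1.2-fold higher number from compound 2 to compound 3 (0.07 log units; within the scatter), probably not beyond the usual scatter. Compound 3 is therefore estimated at 1500 nM in this assay, with a range from 500 nM to 5000 nM.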

Compound 3, half-maximal inhibitory concentration: 4180 nM
The estimate for compound 3 lay 2.8-fold (0.45 log units) below the measured number; the measured number falls inside the stated range.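

In this assay, the exchange on a double-bonded chain carbon bound to a double-bonded chain carbon now has a measured size: 3,4-dichlorophenyl in place of 4-methylphenyl gives a 3.2-fold higher number from compound 2 to compound 3 (0.51 log units; beyond the scatter), a modest step. With 3,4-dichlorophenyl held constant, (dimethylamino)methyl in place of hydrogen on a saturated ring carbon gives an at least 11-fold lower number from compound 1 to compound 3 (1.07 log units; beyond the scatter), a large step and the greater of the two. Its full size cannot be read, as compound 1 gives a limit and not a number: the limit of > 50000 nM in this assay, at which 1 of the 3 values shown sits.

The compounds shown leave open whether a 4-chlorophenyl or a 3-chlorophenyl would fall with either of these two groups. They also leave open how another amine, such as a pyrrolidine, or a longer chain carrying the dimethylamino group would compare.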